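The compounds below may be only part of what the source reports. "The series", "measured", "known", "first", "only" and "open" are said of these compounds alone.

Compound 1 `Cc1[nH]c2ccccc2c(=O)c1C1CCCCC1`: > 41400 nM (a limit)
Compound 2 `Cc1[nH]c2ccccc2c(=O)c1Br`: > 42000 nM (a limit)

In an ADME assay on J774 cells (Mus musculus) for cytotoxicity (a lower number here means that less compound is needed, a higher number that more compound is needed for the effect), compound 2 is known only as a limit, > 42000 nM. The other measured compound, compound 1, is also known only as a limit, > 41400 nM. Compound 3 `COc1ccc2[nH]c(C)c(Br)c(=O)c2c1` carries methoxy in place of hydrogen on an aromatic carbon of compound 2: methoxy in place of hydrogen on an aromatic carbon. Within the data shown here, the only measured step, a step that the two limits leave unreadable from compound 1 to compound 2, involves different groups, and its size cannot be read. It therefore gives no size or direction to carry over, and no change beyond the scatter is expected in this assay. The expected at least 1.1-fold lower number from compound 2 to compound 3 (0.05 log units; that floor lies within the scatter) is correspondingly small. For compound 3, the estimate is 37300 nM, with an expected range of 20000 nM to 60000 nM, quite possibly reported again as a limit.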

Compound 3, half-maximal effective concentration: > 37300 nM
Compound 3 ended at the assay's limit; the forecaster's own chance of this, stated with the estimate: 85%; the middle value sits exactly at the limit.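

Compound 2 and compound 3 are both known only as limits in this assay, so the step between them cannot be read. From the compounds shown here alone, whether methoxy in place of hydrogen on an aromatic carbon changes the result at all stays open.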